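This account rests on a few compounds, and the source may have more. Where it says the series, first, only, none or still open, it means among the compounds named here.

Measured so far:
- compound 1, `COC1CCCN(C(=O)N2CC(c3nc(-c4cccc(Cl)c4)no3)C2)C1`: > 10000 nM
- compound 2, `O=S(=O)(c1ccc(F)cc1)N1CC(c2nc(-c3cccc(Cl)c3)no2)C1`: > 10000 nM

Both measured compounds share the core of compound 1 and differ only in the group attached to the ring nitrogen. In an assay on HEK293 cells for positive allosteric modulation of metabotropic glutamate receptor 5 (Homo sapiens), read by FLIPR (on this read-out higher numbers stand for an effect only at larger amounts of compound and lower numbers for an effect already at smaller amounts), compound 1 gives > 10000 nM, which is a limit of the assay rather than a number. Compound 2 gives > 10000 nM in this assay, again a limit. Compound 1 therefore stands at the limit of > 10000 nM in this assay, at which 2 of the 2 values shown sit, with no measured number to set it apart from compound 2.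

Compound 3, `O=C(C1CCCO1)N1CC(c2nc(-c3cccc(Cl)c3)no2)C1`, is the one still to be measured. It differs from compound 1 in one place: oxolan-2-yl in place of 3-methoxypiperidin-1-yl on a carbonyl carbon. Going by the values given here, no step between two measured compounds is available, and both values sit at the limit, so no direction can be read from the data. The step that the limit leaves unreadable from compound 1 to compound 3 is expected to be none beyond the scatter. Compound 3 is expected to give 15000 nM, within a range from 3000 nM to 60000 nM, and most likely only a limit will be reported.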

Compound 3, half-maximal effective concentration: > 10000 nM
Compound 3: no number, only a limit; the forecaster's own chance of this, stated with the estimate: 80%; the middle value does not contradict the limit.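

In this assay compound 3 gives > 10000 nM, which is a limit and not a number. Compound 1 also sits at a limit, so the change from compound 1 to compound 3 cannot be read as a step. The compounds shown leave open which group at this place, if any, would give a measured number: the limit of > 10000 nM in this assay, at which 3 of the 3 values shown sit.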